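The source may report more compounds than this note shows. Statements on the series, on what has been measured and on what is new or still open speak of the compounds shown alone.

Within the data shown here, compound 2, `CC1=CC[C@H](C(C)C)c2cc(C)c(OC(=O)c3ccccc3)cc21`, stands at the bottom of the two numbers so far in a functional assay on PC-3 cells (Homo sapiens) for antiproliferative activity, read by sulforhodamine B assay, with a stated time of 48 h, tested at 50 uM (a higher number here means more inhibition at the concentration tested (going by the name of the read-out), a lower number less inhibition), where compound 2 gives 22.5%. Among the measured compounds shown here, its only measured neighbour is compound 1, `CC1=CC[C@H](C(C)C)c2cc(C)c(OC(=O)Nc3ccccc3)cc21`, which in this assay gives 93.2%; the single measured step, a number 70.7 percentage points lower from compound 1 to compound 2 (beyond the scatter), is the whole of what is known about how changes on this core move the read-out. Compound 3, `CC1=CC[C@H](C(C)C)c2cc(C)c(OC(=O)c3cccc(C(F)(F)F)c3)cc21`, has not yet been measured. It differs from compound 2 by a (trifluoromethyl in place of hydrogen on an aromatic carbon). For the measured compounds named here, the one measured step bears only loosely on this change: it concerns the group on the carbonyl carbon, whereas the new change sits on the aromatic ring itself, so nothing measured speaks directly to it. Compound 3 is therefore expected to give a step of a number 5.5 percentage points higher from compound 2 to compound 3 (within the scatter), which lies within the scatter. The estimate for compound 3 in this assay is 28%, with a range from 5% to 60%.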

Compound 3, a percentage reported as inhibition, at one concentration (the size of the read-out at that concentration, not a potency): 25.4%
Compound 3: the middle estimate sits 2.6 percentage points above what was measured; measured number inside the range.
By their numbers in this assay, from the lowest: compounds 2 and 3 (each within the scatter of the next); then compound 1.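

In this assay, trifluoromethyl in place of hydrogen on an aromatic carbon, meta to a large group, gives a number 2.9 percentage points higher from compound 2 to compound 3 (within the scatter), so this change on the aromatic ring leaves the read-out without a shift that can be told from scatter. The earlier step, a number 70.7 percentage points lower from compound 1 to compound 2 (beyond the scatter), concerned the group on the carbonyl carbon; this result adds that entering 4 heavy atoms on the ring itself does not produce a change of that kind, at least for this one group at this one place. Nothing measured on these compounds accounts for either step.

Going by these compounds, it remains open whether a different group here, such as an amine, a carboxylic acid or a longer chain, would move the number. Also open, on these data alone, is whether trifluoromethyl would have any larger effect on the aromatic ring of the anilino group in compound 1.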